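The source may report more compounds than this note shows. Statements on the series, on what has been measured and on what is new or still open speak of the compounds shown alone.

Compound 1 `CCCC(=O)OCSc1ccccc1C(=O)NCCC(N)=O`, in an ADME assay on CEM-SS cells (Homo sapiens) for cytotoxicity, read by XTT assay, with a stated time of 6 days; on this read-out lower numbers stand for higher toxicity in this test and higher numbers for lower toxicity in this test: > 100 uM.
Compound 2 `NC(=O)CCNC(=O)c1cccc(S)c1`: > 100 uM.
Compound 3 `CCCC(=O)OCSc1ccccc1C(=O)NCCCCCCNC(C)=O`: 8 uM.

Compound 1 gives a value that is a limit of this assay and not a number, so its standing is known only as a bound, not a point. Compound 2 likewise stands at a limit. Among the measured compounds shown here, compound 3 is the only compound with a measured number. For the measured compounds named here, the one step that is measured, an at least 12-fold lower number from compound 1 to compound 3 (1.09 log units; beyond the scatter), is large and beyond the scatter, but it swaps in a long 4-acetamidobutyl chain, a change of a different kind from the one considered here.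

Compound 4 `CCCC(=O)OCSc1ccccc1C(=O)NCC(=O)NC` differs from compound 1 in this way: methylcarbamoyl in place of carbamoylmethyl on a saturated chain carbon bound to an amide-type nitrogen. The two compounds share every atom; the difference is only how the chain beyond the amide-type nitrogen is joined. Going by the values given here, no measured step speaks to such a rearrangement, and because the limit of > 100 uM in this assay, at which 2 of the 3 values shown sit, most of the data sit at the bound, the expectation rests on compound 1 alone. The step from compound 1 to compound 4 is expected to be a number no higher from compound 1 to compound 4 (the limit leaves the size open), no change beyond the scatter. Compound 4 is therefore estimated at 100 uM, within 40 uM to 300 uM, and it is expected that this assay most likely again reports only a limit.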

Compound 4, half-maximal toxic concentration: > 100 uM
Compound 4 ended at the assay's limit; the forecaster's own chance of this, stated with the estimate: 70%; the middle value lies on the limit itself.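

In this assay compound 4 gives > 100 uM, which is a limit of the assay and not a number. The step that swaps carbamoylmethyl for methylcarbamoyl on a saturated chain carbon bound to an amide-type nitrogen cannot be read, since both of its ends are limits: the limit of > 100 uM in this assay, at which 3 of the 4 values shown sit. The step that can be read is an at least 12-fold higher number from compound 3 to compound 4 (1.09 log units; beyond the scatter), with methylcarbamoyl in place of 5-acetamidopentyl, so that among the compounds shown only the one carrying the long chain gives a measured number.

From the compounds shown here alone, how short the chain at this place can become before the number rises remains open. Also open, going by these compounds, is whether a chain ending in an amine or a carboxylic acid, in place of the acetamide of compound 3, would give a measured number in this assay.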